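A few compounds are considered here, and "the series" means these few. Any claim that something is new, unique, unknown or untested is made for them only; others in the source may bear on it.

In a functional assay on HT-29 cells (Homo sapiens) for inhibition, read by MTT assay, with a stated time of 3 days (on this read-out higher numbers stand for weaker inhibition and lower numbers for stronger inhibition), compound 1 (`COc1cccc(/C=C/CCCOc2cc(/C=C\c3cc(OC)c(OC)c(OC)c3)ccc2OC)c1`) gives 25000 nM, compound 2 (`COc1ccc(/C=C/CCCOc2cc(/C=C\c3cc(OC)c(OC)c(OC)c3)ccc2OC)cc1`) gives 47000 nM and compound 3 (`COCOc1cccc(/C=C/CCCOc2cc(/C=C\c3cc(OC)c(OC)c(OC)c3)ccc2OC)c1`) gives 59000 nM. Compound 3 therefore stands apart from only one of the others: the numbers show a 2.4-fold higher number from compound 1 to compound 3 (0.37 log units; beyond the scatter), but only a 1.3-fold higher number from compound 2 to compound 3 (0.10 log units; within the scatter). Compound 4 (`COCOc1ccc(/C=C/CCCOc2cc(/C=C\c3cc(OC)c(OC)c(OC)c3)ccc2OC)cc1`) has the same atoms as compound 3, joined differently: 4-(methoxymethoxy)phenyl in place of 3-(methoxymethoxy)phenyl on a double-bonded chain carbon bound to a double-bonded chain carbon. The closest measured parallel is the matching change with 4-methoxyphenyl in place of 3-methoxyphenyl, a 1.9-fold higher number from compound 1 to compound 2 (0.27 log units; within the scatter). That single parallel points to a small rise at most, and no change beyond the scatter is expected. The expected step is a 1.2-fold higher number from compound 3 to compound 4 (0.07 log units; within the scatter). Compound 4 is estimated at 70000 nM, with an expected range of 30000 nM to 150000 nM.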

Compound 4, half-maximal inhibitory concentration: 7000 nM
For compound 4 the middle estimate is 10-fold (1.00 log units) above the measured one, and the stated range ends above it.
By their numbers in this assay, from the lowest: compound 4; then compounds 1, 2 and 3 (each within the scatter of the next, the first and the last beyond it).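

In this assay, the 4-(methoxymethoxy)phenyl group in place of 3-(methoxymethoxy)phenyl gives an 8.4-fold lower number from compound 3 to compound 4 (0.93 log units; beyond the scatter), a step beyond the scatter, which the methoxy pair did not show. Compound 4 also stands clear of the two methoxy compounds, with a 6.7-fold lower number from compound 2 to compound 4 (0.83 log units; beyond the scatter) and a 3.6-fold lower number from compound 1 to compound 4 (0.55 log units; beyond the scatter). The exchange of methoxy for methoxymethoxy therefore runs in opposite directions on the two cores: the same change on two cores in this assay, a 2.4-fold higher number (0.37 log units; beyond the scatter) from compound 1 to compound 3 and a 6.7-fold lower number (0.83 log units; beyond the scatter) from compound 2 to compound 4, 16-fold (1.20 log units) apart, beyond the scatter of two such steps.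

As far as these compounds go, what remains open is whether a 4-hydroxyphenyl or 4-ethoxyphenyl group on the same chain would read like compound 4 or like compound 2. From the compounds shown here alone, how a longer chain would alter the result with 4-(methoxymethoxy)phenyl also remains open.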